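Working notes: extending the allyl arm by a phenyl ring

This account rests on a few compounds, and the source may have more. Where it says the series, first, only, none or still open, it means among the compounds named here.

Two compounds of the series have been run in a functional assay on THP-1 cells (Homo sapiens) for inhibition, read by sulforhodamine B assay, with a stated time of 48 h; a lower number here means a stronger inhibitor, a higher number a weaker inhibitor. Compound 1 `COc1ccc(/C(=N/O)c2cccc3ccccc23)c(OC)c1OC` gives only a limit there, > 20000 nM. Compound 2 `C=CCC(O)(c1ccc(OC)c(OC)c1OC)c1cccc2ccccc12` likewise gives only a limit, > 20000 nM. Both results rest on (the limit of > 20000 nM in this assay, at which 2 of the 2 values shown sit), so compound 2 stands indistinguishable from compound 1 on the numbers shown. Compound 3 `COc1ccc(C(O)(C/C=C\c2ccccc2)c2cccc3ccccc23)c(OC)c1OC` differs from compound 2 by 2-phenylethenyl in place of vinyl on a saturated chain carbon, two bonds along the chain from two aromatic carbons and an oxygen on a saturated carbon. Within the data shown here, no measured step covers such a change, so the step expected in this assay is an at least 1.3-fold lower number from compound 2 to compound 3 (0.12 log units; that floor lies within the scatter), modest and toward somewhat stronger inhibition at most. Compound 3 is accordingly estimated at 15000 nM, within 3000 nM to 60000 nM.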

Compound 3, half-maximal inhibitory concentration: 19400 nM
Compound 3: the middle estimate sits 1.3-fold (0.11 log units) below what was measured; measured number inside the range.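

In this assay, among these compounds, the change from allyl to 3-phenylprop-2-en-1-yl gives an at least 1.0-fold lower number from compound 2 to compound 3 (0.01 log units; that floor lies within the scatter), the first step that can be read at this position. Among the compounds shown here, compound 3 gives 19400 nM, the first number that is not a limit. The step is only a floor, because compound 2 sits at a limit: the limit of > 20000 nM in this assay, at which 2 of the 3 values shown sit.

Going by these compounds, the true size of the change remains open. Also open, on these data alone, is whether an amine or a carboxylic acid in place of the 2-phenylethenyl would shift the number in this assay beyond the scatter.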